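The compounds below may be only part of what the source reports. "The series", "measured", "known", "first", "only" and "open" are said of these compounds alone.

Measured compounds:
compound 1, `N#Cc1ccc(C(c2ccc(C#N)cc2)n2cc(COc3ccc(-c4ccccc4)cc3)nn2)cc1`, 13400 nM
compound 2, `N#Cc1ccc(Cn2cc(COc3ccc(-c4ccccc4)cc3)nn2)cc1`, 11600 nM

In an assay on isolated protein for inhibition of Aromatase (Homo sapiens), read by fluorescence and colorimetric assay, with a stated time of 30 min (on this read-out lower numbers stand for stronger inhibition and higher numbers for weaker inhibition), compound 1 gives 13400 nM and compound 2 gives 11600 nM. Among the compounds with values here, compound 2 carries the lowest of the two numbers measured so far, but the step of a 1.2-fold lower number from compound 1 to compound 2 (0.06 log units; within the scatter) is within the scatter, so the two compounds cannot be separated on these data. The next compound, compound 3 `c1ccc(Cn2cc(COc3ccc(-c4ccccc4)cc3)nn2)cc1`, differs from compound 2 in one place: hydrogen in place of cyano on an aromatic carbon. Within the data shown here, no measured step removes exactly this cyano group. Among the measured compounds shown here, the only step available took away a whole 4-cyanophenyl from the chain carbon and left the number essentially where it was, which speaks for little sensitivity to groups in that part of the molecule; it does not test the cyano on the remaining benzyl group directly. For the measured compounds named here, with that single, loosely related step as the only guide, a small weakening is expected, and the step of a 1.7-fold higher number from compound 2 to compound 3 (0.24 log units; within the scatter) is the estimate. Compound 3 is therefore expected to give about 20000 nM, with a range from 8000 nM to 60000 nM.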

Compound 3, half-maximal inhibitory concentration: 10700 nM
For compound 3 the middle estimate is 1.9-fold (0.27 log units) above the measured one; the range from low to high includes it.
By their numbers in this assay, from the lowest: compounds 3, 2 and 1 (each within the scatter of the next).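

In this assay, removing the cyano group from the aromatic carbon, which turns 4-cyanobenzyl into benzyl, gives a 1.1-fold lower number from compound 2 to compound 3 (0.04 log units; within the scatter), so this pair cannot be told apart. The earlier step took away a whole 4-cyanophenyl from the chain carbon and so never tested this cyano group on its own; this pair does, and it shows that the cyano group, a nitrile sitting para to a large group, can be replaced by hydrogen with no change that rises above the scatter of repeated measurements. Nothing available bears on why the number responds so little to this swap.

The compounds shown leave open whether any other group on this same aromatic carbon, such as an amine, a carboxylic acid or a methoxy group, would give a number clearly apart from those of compound 2 and compound 3. They also leave open whether a change elsewhere in the shared core, such as a longer chain, would move the number beyond the scatter, something neither step here does.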